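A methylsulfonyl swap in a series sitting at a limit

A few compounds are considered here, and "the series" means these few. Any claim that something is new, unique, unknown or untested is made for them only; others in the source may bear on it.

Compound 1 `CC(C)C(=O)N1C[C@H](NC(=O)c2ccc(-n3ccccc3=O)cc2)[C@H](NC(=O)c2ccc(Cl)s2)C1` gives > 100000 nM as a limit of the assay
Compound 2 `O=C(N[C@H]1CN(C(=O)C2CC2)C[C@H]1NC(=O)c1ccc(Cl)s1)c1ccc(-n2ccccc2=O)cc1` gives > 100000 nM as a limit of the assay
Compound 3 `COCC(=O)N1C[C@H](NC(=O)c2ccc(-n3ccccc3=O)cc2)[C@H](NC(=O)c2ccc(Cl)s2)C1` gives > 100000 nM as a limit of the assay

In an ADME assay on HEK293 cells (Homo sapiens) for cytotoxicity (on this read-out lower numbers stand for stronger inhibition and higher numbers for weaker inhibition), compound 3 stands at > 100000 nM and this is a limit, not a number. Among the compounds with values here, it has no place of its own in the set, which shares the limit of > 100000 nM in this assay, at which 3 of the 3 values shown sit, as its only reading. Compound 4 `CS(=O)(=O)N1C[C@H](NC(=O)c2ccc(-n3ccccc3=O)cc2)[C@H](NC(=O)c2ccc(Cl)s2)C1` carries methylsulfonyl in place of (methoxymethyl)carbonyl on an amine nitrogen in a ring. The measured steps that bear on this all concern the group on the carbonyl carbon at that nitrogen: a step that the two limits leave unreadable from compound 1 to compound 2, a step that the two limits leave unreadable from compound 1 to compound 3 and a step that the two limits leave unreadable from compound 2 to compound 3. None of them has a readable size or direction, and none removes the carbonyl itself. No step beyond the usual scatter is therefore expected, in either direction (a number no higher from compound 3 to compound 4 (the limit leaves the size open)). Compound 4 is estimated at 100000 nM and expected to fall from 50000 nM to 200000 nM on this read-out.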

Compound 4, half-maximal inhibitory concentration: > 100000 nM
Compound 4 was reported as a limit; the forecaster's own chance of this, stated with the estimate: 85%; the middle value lies on the limit itself.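

Compound 4 gives > 100000 nM, which is a limit of the assay and not a number. Its steps from compound 1, compound 2 and compound 3 therefore cannot be read. The compounds shown leave open whether the group on the amine nitrogen in the ring changes the value at all, as they all share one limit: the limit of > 100000 nM in this assay, at which 4 of the 4 values shown sit.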